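The source may hold more compounds than are shown below. What is called first, only, known or untested is meant among the compounds shown, and "the series" means these compounds.

Measured compounds:
compound 1 `O=C(O)c1cccc(C2CC2c2ccc(OCc3c(-c4c(Cl)cccc4Cl)noc3C3CC3)cc2Cl)c1`, 34 nM
compound 2 `O=C(O)c1cncc(C2CC2c2ccc(OCc3c(-c4c(Cl)cccc4Cl)noc3C3CC3)cc2Cl)c1`, 14 nM
compound 3 `O=C(O)c1ccc(C2CC2c2ccc(OCc3c(-c4c(Cl)cccc4Cl)noc3C3CC3)cc2Cl)cn1`, 57 nM

In an assay on HEK293 cells for agonist activity at Bile acid receptor (Homo sapiens) (a higher number here means that more compound is needed for the effect, a lower number that less compound is needed), compound 3 gives the highest of the three numbers. Its nearest neighbour is compound 1 with 34 nM, and that gap, a 1.7-fold higher number from compound 1 to compound 3 (0.22 log units; within the scatter), lies within the scatter. The furthest is compound 2, and the step of a 4.1-fold higher number from compound 2 to compound 3 (0.61 log units; beyond the scatter) lies beyond it.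

Compound 4 `O=C(O)c1cccc([C@@H]2C[C@H]2c2ccc(OCc3c(-c4c(Cl)cccc4Cl)noc3C3CC3)cc2Cl)c1` is the unmeasured compound. The change from compound 3 is 2-(3-carboxyphenyl)cyclopropyl in place of 2-(6-carboxypyridin-3-yl)cyclopropyl on an aromatic carbon, and the entering group carries two defined stereocentres. Compound 4 therefore shares its connectivity with compound 1, whose stereocentres are undefined. The step that bears on this change is a 1.7-fold higher number from compound 1 to compound 3 (0.22 log units; within the scatter), run backwards; it was within the scatter. Among the measured compounds shown here, the only step beyond the scatter, a 2.4-fold lower number from compound 1 to compound 2 (0.39 log units; beyond the scatter), concerns a different ring and does not apply here.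

Compound 4 is therefore expected to give a number close to that of compound 1, and the estimated step is a 2.3-fold lower number from compound 3 to compound 4 (0.36 log units; beyond the scatter). The estimate for compound 4 in this assay is 25 nM, with a range of 9 nM to 70 nM.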

Compound 4, half-maximal effective concentration: 29 nM
For compound 4 the middle estimate is 1.2-fold (0.06 log units) below the measured one, within the range that was stated.
By their numbers in this assay, from the lowest: compound 2; then compounds 4, 1 and 3 (each within the scatter of the next).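

Drawing both saturated ring carbons of the cyclopropyl group with a defined configuration, R at each, gives no separable change in this assay, with a 1.2-fold lower number from compound 1 to compound 4 (0.07 log units; within the scatter), and the only difference behind that step is this: the fact that one of compounds 1 and 4 is drawn with a defined configuration and the other without, at the place where they differ Against the 2-(6-carboxypyridin-3-yl)cyclopropyl group, the 2-(3-carboxyphenyl)cyclopropyl group in this configuration gives a 2.0-fold lower number from compound 3 to compound 4 (0.29 log units; within the scatter), which also stays within the scatter. Against the 2-(5-carboxypyridin-3-yl)cyclopropyl group it gives a 2.1-fold higher number from compound 2 to compound 4 (0.32 log units; beyond the scatter), so that pyridine alone stands apart from the defined compound, as it did from the undefined one.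

The compounds shown leave open how the opposite configuration at these two ring carbons would read, and whether a defined configuration would shift either pyridine compound. They also leave open how an amide or a tetrazole would read in place of the carboxylic acid.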